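The compounds below may be only part of what the source reports. "The series", "measured", "known", "first", "only" and "open" are said of these compounds alone.

Compound 1, `CN(C)CCn1cnnc1-c1cc(Oc2ccc(NC(=O)N/N=C/c3ccccc3O[N+](=O)[O-])cc2F)ccn1`: 7150 nM in a functional assay on U-87MG ATCC cells (Homo sapiens) for cytotoxicity, read by MTT assay, with a stated time of 72 h; a lower number here means a stronger inhibitor, a higher number a weaker inhibitor.
Compound 2, `CN(C)CCn1cnnc1-c1cc(Oc2ccc(NC(=O)N/N=C/c3ccc(F)cc3F)cc2F)ccn1`: 1900 nM in this assay.
Compound 3, `COc1cc(/C=N/NC(=O)Nc2ccc(Oc3ccnc(-c4nncn4CCN(C)C)c3)c(F)c2)cc(OC)c1OC`: 22500 nM in this assay.

Compound 3 stands highest of these three numbers, the weakest inhibitor of the set: compound 1 is nearest (a 3.1-fold higher number from compound 1 to compound 3 (0.50 log units; beyond the scatter)) and compound 2 furthest (a 12-fold higher number from compound 2 to compound 3 (1.07 log units; beyond the scatter)).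

Compound 4, `CN(C)CCn1cnnc1-c1cc(Oc2ccc(NC(=O)N/N=C/c3ccc(Cl)cc3)cc2F)ccn1`, differs from compound 3 by 4-chlorophenyl in place of 3,4,5-trimethoxyphenyl on a carbon with a double bond to nitrogen. For the measured compounds named here, the steps that bear on this are a 12-fold higher number from compound 2 to compound 3 (1.07 log units; beyond the scatter) and a 3.1-fold higher number from compound 1 to compound 3 (0.50 log units; beyond the scatter), both rising when the trimethoxyphenyl entered; a halogenated phenyl, as in compound 2, now takes its place. Compound 4 is therefore expected to give a clearly lower number, a step of a 9.0-fold lower number from compound 3 to compound 4 (0.95 log units; beyond the scatter). The value of compound 4 in this assay is estimated at 2500 nM, within 900 nM to 7000 nM.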

Compound 4, half-maximal inhibitory concentration: 1370 nM
The estimate for compound 4 lay 1.8-fold (0.26 log units) above the measured number, within the range that was stated.
By their numbers in this assay, from the lowest: compounds 4 and 2 (each within the scatter of the next); then compound 1; then compound 3.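

Swapping 3,4,5-trimethoxyphenyl for 4-chlorophenyl on the carbon with a double bond to nitrogen gives the largest change so far (a 16-fold lower number from compound 3 to compound 4 (1.22 log units; beyond the scatter)). Compound 4 also improves on the nitrooxy-bearing compound (a 5.2-fold lower number from compound 1 to compound 4 (0.72 log units; beyond the scatter)), but 4-chlorophenyl and 2,4-difluorophenyl cannot be told apart (a 1.4-fold lower number from compound 2 to compound 4 (0.14 log units; within the scatter)), so two differently halogenated phenyl groups perform alike here. No measurement available here explains these differences. Still open, from the compounds shown here alone, is whether a bromophenyl would perform like these two, and how a phenyl carrying an amine or a carboxylic acid would compare.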